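The compounds below may be only part of what the source reports. "The series", "measured", "known", "first", "only" and "open" are said of these compounds alone.

Among the measured compounds shown here, compound 1 `O=C(CCCCCCc1cccc(F)c1)N1CCCC1` is one of three compounds measured in an assay on HEK293 cells for inhibition of N-acylethanolamine-hydrolyzing acid amidase (Rattus norvegicus), read by LC-MS, with a stated time of 30 min (a higher number here means a weaker inhibitor, a lower number a stronger inhibitor), where compound 1 gives 7300 nM. Of the other two, compound 3 `O=C(CCCCCCc1ccc(O)cc1)N1CCCC1` gives 5600 nM, a value that lies within the scatter of the value of compound 1, so the two cannot be told apart here. Compound 2 `Cc1cccc(-c2ccc(CCC(=O)N3CCCC3)cc2)c1` gives 16500 nM, a higher number than that of compound 1 by a margin beyond the scatter. Compound 1 therefore sits with the second highest of the three numbers, close to compound 3 and clearly apart from compound 2.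

Compound 4 `COC(=O)c1cccc(CCCCCCC(=O)N2CCCC2)c1` has not yet been measured. It differs from compound 1 in one place: methoxycarbonyl in place of fluoro on an aromatic carbon. For the measured compounds named here, no step between measured compounds matches this change, so nothing in the data shows what a methoxycarbonyl in place of a fluoro does in this assay. Without such a step, the expectation rests on compound 1 alone: the step from compound 1 to compound 4 is expected to be a 1.1-fold higher number from compound 1 to compound 4 (0.04 log units; within the scatter), no larger than the scatter in either direction. Compound 4 is accordingly estimated at 8000 nM, within a range from 3000 nM to 22000 nM.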

Compound 4, half-maximal inhibitory concentration: > 100000 nM
Compound 4: a limit, no number; the forecaster's own chance of this, stated with the estimate: 10%; at least 12-fold (1.09 log units) between middle value and limit.
By their numbers in this assay, from the lowest: compounds 3 and 1 (each within the scatter of the next); then compound 2. At a limit, above all of these: compound 4.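

Among the compounds shown here, the aromatic carbon meta to a large group does not accept every substituent: methoxycarbonyl in place of fluoro gives an at least 13-fold higher number from compound 1 to compound 4 (1.13 log units; beyond the scatter) in this assay, a large step where the earlier compounds offered no step at this place. On these data alone, compound 4 carries a limit and not a number, so the full size of this step stays unknown: the limit of > 100000 nM in this assay, at which 1 of the 4 values shown sits. The entering group brings hydrogen-bond acceptors and a double bond outside aromatic rings that fluoro lacks, but these changes arrive together and the data cannot separate them.

The compounds shown leave open whether a carboxylic acid, a methoxy group or an amine on this aromatic carbon would behave like fluoro or like methoxycarbonyl. They also leave open how methoxycarbonyl would fare elsewhere on the ring or with a shorter chain.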